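This account rests on a few compounds, and the source may have more. Where it says the series, first, only, none or still open, it means among the compounds named here.

Measured so far in a functional assay on MDA-MB-231 cells (Homo sapiens) for cytotoxicity, read by MTT assay, with a stated time of 24 h; on this read-out lower numbers stand for stronger inhibition and higher numbers for weaker inhibition:
compound 1 `CCCCCCCCCC(=O)Nc1nnc(S[C@@H]2O[C@H](CO)[C@H](O)[C@H](O)[C@H]2O)s1` gives 53100 nM
compound 2 `CCCCCCCC(=O)Nc1nnc(S[C@@H]2O[C@H](CO)[C@H](O)[C@H](O)[C@H]2O)s1` gives 30800 nM

Compound 1 holds the higher of these two numbers; its nearest neighbour is compound 2, with a 1.7-fold lower number from compound 1 to compound 2 (0.24 log units; within the scatter), within the scatter. Compound 3 `CCCCCCCC/C=C\CCCCCCCCCCCC(=O)Nc1nnc(S[C@@H]2O[C@H](CO)[C@H](O)[C@H](O)[C@H]2O)s1` is derived from compound 1 by dodec-3-en-1-yl in place of hydrogen on a saturated chain carbon, nine bonds along the chain from a carbonyl carbon. Within the data shown here, the only step that bears on chain length is the one a 1.7-fold lower number from compound 1 to compound 2 (0.24 log units; within the scatter), a small shift toward a higher number with the longer chain. The chain of compound 3 is far longer than either, beyond what the two steps cover. For compound 3 the expected change is a 1.4-fold higher number from compound 1 to compound 3 (0.15 log units; within the scatter), at most a modest rise in number. Compound 3 is estimated at 75000 nM, range 25000 nM to 220000 nM.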

Compound 3, half-maximal inhibitory concentration: 70400 nM
For compound 3 the middle estimate is 1.1-fold (0.03 log units) above the measured one; low and high end bracket the measured number.
By their numbers in this assay, from the lowest: compounds 2, 1 and 3 (each within the scatter of the next, the first and the last beyond it).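

In this assay, dodec-3-en-1-yl in place of hydrogen on this saturated chain carbon, nine bonds along the chain from a carbonyl carbon, gives a 1.3-fold higher number from compound 1 to compound 3 (0.12 log units; within the scatter) and stays within the scatter. This position therefore accepts dodec-3-en-1-yl, with its one double bond, with no step beyond the scatter, a far larger change than the ethyl of the earlier step. No measured evidence accompanies this result to account for it. Open, as far as these compounds go, is whether an amine or a carboxylic acid at the end of the chain would give a step beyond the scatter.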